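Replacing tert-butoxycarbonyl with pyridin-4-yl: stability outlook

The source may hold more compounds than are shown below. What is called first, only, known or untested is meant among the compounds shown, and "the series" means these compounds.

Compound 3 `CC(C)(C)OC(=O)[C@H](O)[C@H]1C(=O)N2C(C(=O)O)=C(C(C)(C)C)O[C@H]12` gives 10.7 h in an ADME assay, in phosphate buffer, at 28 degrees C, at pH 7.0 (on this read-out higher numbers stand for a longer-lived compound and lower numbers for a shorter-lived compound), the highest of the three numbers. Its nearest neighbour, compound 2 `C[C@H](O)[C@H]1C(=O)N2C(C(=O)O)=C(C(C)(C)C)O[C@H]12`, gives 7.1 h, and a 1.5-fold higher number from compound 2 to compound 3 (0.18 log units; within the scatter). Compound 1 `CC(C)(C)C1=C(C(=O)O)N2C(=O)[C@H](CO)[C@H]2O1` gives 5 h, and a 2.1-fold higher number from compound 1 to compound 3 (0.33 log units; beyond the scatter). Compound 4 `CC(C)(C)C1=C(C(=O)O)N2C(=O)[C@H]([C@@H](O)c3ccncc3)[C@H]2O1` differs from compound 3 in a single place: pyridin-4-yl in place of tert-butoxycarbonyl on a saturated chain carbon bound to an oxygen on a saturated carbon and a saturated ring carbon. Going by the values given here, the steps that bear on this are the earlier changes at the same position: a 1.4-fold higher number from compound 1 to compound 2 (0.15 log units; within the scatter) and a 2.1-fold higher number from compound 1 to compound 3 (0.33 log units; beyond the scatter), so exchanges there have shifted this assay only modestly at most. The analyst therefore expects no step beyond the scatter in this assay, with a 1.4-fold lower number from compound 3 to compound 4 (0.15 log units; within the scatter). Compound 4 is estimated at 7.5 h, within the range 3.5 h to 15 h.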

Compound 4, half-life: 6 h
Compound 4: the middle estimate sits 1.3-fold (0.10 log units) above what was measured, and the stated range covers the measured number.
By their numbers in this assay, from the lowest: compounds 1, 4, 2 and 3 (each within the scatter of the next, the first and the last beyond it).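

On this saturated chain carbon, this assay shows a 1.8-fold lower number from compound 3 to compound 4 (0.25 log units; within the scatter) and a 1.2-fold lower number from compound 2 to compound 4 (0.07 log units; within the scatter) and a 1.2-fold higher number from compound 1 to compound 4 (0.08 log units; within the scatter) for pyridin-4-yl in place of tert-butoxycarbonyl, methyl and hydrogen in turn. The earlier compounds shown here held no ring at this place, and compound 4 shows that a six-membered aromatic ring can sit there and remain within the scatter of all three, although compound 1 and compound 3 lie beyond it from each other. Nothing measured here accounts for this result.

Going by these compounds, whether a phenyl ring, an amine or a carboxylic acid on this carbon would also stay within that span remains open.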